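The source may report more compounds than this note shows. Statements on the series, on what has been measured and on what is new or still open speak of the compounds shown alone.

In a functional assay on A549 cells (Homo sapiens) for antiproliferative activity, read by MTT assay, with a stated time of 72 h (a higher number here means a weaker inhibitor, a lower number a stronger inhibitor), the measured compounds read:
Compound 1 `CC(Oc1nc(N)nc2ccc(-c3cnn(C4CCNCC4)c3)cc12)c1c(Cl)ccc(F)c1Cl`: 9490 nM
Compound 2 `CC(Oc1ncnc2ccc(-c3cnn(C4CCNCC4)c3)cc12)c1c(Cl)ccc(F)c1Cl`: 6750 nM
Compound 3 `CC(Nc1nc(N)nc2ccc(-c3cnn(C)c3)cc12)c1c(Cl)ccc(F)c1Cl`: > 100000 nM (a limit, not a number)

Going by the values given here, compound 2 holds one of only two true numbers in this set, and it lies within the scatter of compound 1. The step of a 1.4-fold lower number from compound 1 to compound 2 (0.15 log units; within the scatter) concerns hydrogen in place of amino. Compound 4 `CC(Oc1ncnc2ccc(-c3cnn(C)c3)cc12)c1c(Cl)ccc(F)c1Cl` keeps the core of compound 2 and changes a different group: methyl in place of piperidin-4-yl on an aromatic nitrogen. Among the compounds with values here, no measured step isolates this change, and the one measured step, at another place, gives no size for it. Only compound 3 carries the methyl, and it differs from compound 2 in other places as well. The expectation rests on compound 3, whose > 100000 nM is a limit of the assay. On this thin evidence, a move toward a higher number, meaning a weaker inhibitor, is expected in this assay. The expected size is a 3.7-fold higher number from compound 2 to compound 4 (0.57 log units; beyond the scatter), and it is uncertain. For compound 4 the estimated value is 25000 nM, with an expected range from 8000 nM to 90000 nM.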

Compound 4, half-maximal inhibitory concentration: 28800 nM
The estimate for compound 4 lay 1.2-fold (0.06 log units) below the measured number; the range from low to high includes it.
By their numbers in this assay, from the lowest: compounds 2 and 1 (each within the scatter of the next); then compound 4. At a limit, above all of these: compound 3.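

In this assay, methyl in place of piperidin-4-yl on the aromatic nitrogen gives a 4.3-fold higher number from compound 2 to compound 4 (0.63 log units; beyond the scatter), a modest step beyond the scatter and the first measured size for a change at this position. The earlier step, hydrogen in place of amino, lay at another place and stayed within the scatter, so of the two steps shown, only this one moves the number beyond the scatter. Compound 3 also carries the methyl, but it differs from compound 4 in more than one place and its reading is only a limit: the limit of > 100000 nM in this assay, at which 1 of the 4 values shown sits.

Only piperidin-4-yl and methyl are shown on this nitrogen, and both steps are read on a single pair of compounds each. On these data alone, whether the higher number goes with the loss of the ring nitrogen or of the ring itself stays open, and a cyclohexyl ring or an aminoethyl chain at this position would separate the two.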